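A Third Heteroaryl on the Sulfonamide Nitrogen

The source may report more compounds than this note shows. Statements on the series, on what has been measured and on what is new or still open speak of the compounds shown alone.

Of the compounds shown here, three have so far been measured in a functional assay on HT-1080 cells (Homo sapiens) for antiproliferative activity, read by sulforhodamine B assay, with a stated time of 48 h; a higher number here means a weaker inhibitor, a lower number a stronger inhibitor. Compound 1 `Nc1ccc(S(=O)(=O)Nc2ccnc3cc(C(F)(F)F)ccc23)cc1` gives 29600 nM. Compound 2 `Cc1noc(NS(=O)(=O)c2ccc(N/C(S)=N\c3ccnc4cc(C(F)(F)F)ccc34)cc2)c1C` gives 27700 nM, and compound 3 `O=S(=O)(Nc1nccs1)c1ccc(N/C(S)=N\c2ccnc3cc(C(F)(F)F)ccc23)cc1` gives 27300 nM. On paper compound 3 holds the lowest of the three numbers, but its gap to compound 2 and its gap to compound 1 both lie within the scatter, so the three are indistinguishable in this assay.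

Compound 4 `Cc1cc(C)nc(NS(=O)(=O)c2ccc(N/C(S)=N\c3ccnc4cc(C(F)(F)F)ccc34)cc2)n1` has not yet been measured. It differs from compound 3 in one place: 4,6-dimethylpyrimidin-2-yl in place of 1,3-thiazol-2-yl on a sulfonamide nitrogen. For the measured compounds named here, the one measured step that bears on this change is a 1.0-fold lower number from compound 2 to compound 3 (0.01 log units; within the scatter), in which one heteroaryl replaced another on the same sulfonamide nitrogen without moving the number beyond the scatter. Compound 1, which lacks the whole heteroaryl sulfonamide arm, also gives a number within the scatter of compound 3. Every change seen so far has thus left this assay flat. On that basis the expected step is a 1.0-fold lower number from compound 3 to compound 4 (0.00 log units; within the scatter), nothing beyond the scatter in either direction. Compound 4 is therefore estimated at 27000 nM, with a range from 12000 nM to 60000 nM.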

Compound 4, half-maximal inhibitory concentration: 29500 nM
For compound 4 the middle estimate is 1.1-fold (0.04 log units) below the measured one; the range from low to high includes it.
By their numbers in this assay, from the lowest: compounds 3, 2, 4 and 1 (each within the scatter of the next).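

In this assay, for the compounds shown here, the sulfonamide nitrogen now carries a third heteroaryl, and 4,6-dimethylpyrimidin-2-yl is the first six-membered aromatic ring at this place, with 8 heavy atoms where 1,3-thiazol-2-yl has 5. Even so, the exchange gives a 1.1-fold higher number from compound 3 to compound 4 (0.03 log units; within the scatter) and no separation between the two compounds, while the exchange for 3,4-dimethyl-1,2-oxazol-5-yl gives a 1.1-fold higher number from compound 2 to compound 4 (0.03 log units; within the scatter) and likewise no separation. Going by these compounds alone, the earlier step compared only two five-membered rings, whereas these steps show that a larger six-membered ring with two methyl groups on this nitrogen also stays within the scatter.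

The compounds shown leave open whether a group of another kind on this nitrogen, such as a plain methyl, a carboxylic acid or a longer alkyl chain, would move the number at all. They also leave open whether a change away from this nitrogen, for instance an amine or a nitrile in place of the trifluoromethyl on the shared core, would leave this assay as flat as it has been so far. No other measurement is at hand to account for this flatness.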